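The source may report more compounds than this note shows. Statements on the series, on what has been measured and on what is new or still open speak of the compounds shown alone.

Compound 1, `COc1cc(-c2cc(/C=C/C(=O)c3ccc(N)cc3)[nH]n2)cc(OC)c1OC`, gives -94% in a functional assay on SK-MEL-5 cells (Homo sapiens) for cytotoxicity, read by sulforhodamine B assay, with a stated time of 48 h, tested at 100 uM; a lower number here means a stronger effect, a higher number a weaker effect of the compound at the concentration tested. Compound 2, `COc1cc(-c2cc(/C=C/C(=O)c3ccc(Cl)c(Cl)c3)[nH]n2)cc(OC)c1OC`, gives -30%. Compound 3, `COc1ccc(C(=O)/C=C/c2cc(-c3cc(OC)c(OC)c(OC)c3)n[nH]2)cc1OC`, gives -92%.

Compound 3 stands second highest of the three numbers: its nearest neighbour is compound 1, with a number 2 percentage points higher from compound 1 to compound 3 (within the scatter), while a number 62 percentage points lower from compound 2 to compound 3 (beyond the scatter) sets compound 2 far apart. Compound 4, `COc1ccc(C(=O)/C=C/c2cc(-c3cc(OC)c(OC)c(OC)c3)n[nH]2)cc1`, differs from compound 3 by hydrogen in place of methoxy on an aromatic carbon. Among the compounds with values here, no measured step removes a single methoxy; the steps seen all exchange the whole aryl group on the carbonyl, one of them small (a number 2 percentage points higher from compound 1 to compound 3 (within the scatter)) and the others large (a number 64 percentage points higher from compound 1 to compound 2 (beyond the scatter)). Compound 4 is therefore expected to stay close to compound 3, with a number 7 percentage points higher from compound 3 to compound 4 (within the scatter) estimated to lie within the scatter or only slightly above it. Compound 4 is estimated at -85%, in the range -99% to -55%.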

Compound 4, a percentage reported as activity, at one concentration (the size of the read-out at that concentration, not a potency): -93%
For compound 4 the middle estimate is 8 percentage points above the measured one; the measured number falls inside the stated range.
By their numbers in this assay, from the lowest: compounds 1, 4 and 3 (each within the scatter of the next); then compound 2.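

In this assay, within the data shown here, the step of a number 1 percentage points lower from compound 3 to compound 4 (within the scatter) is the first to alter a single methoxy, showing that hydrogen can take its place on this aromatic carbon with a step that stays within the scatter. The step of a number 1 percentage points higher from compound 1 to compound 4 (within the scatter) also stays within the scatter, while the step of a number 63 percentage points lower from compound 2 to compound 4 (beyond the scatter) is large and beyond it. Nothing available explains why this methoxy can be replaced by hydrogen in this way. Still open, as far as these compounds go, is whether a hydroxy group or a fluorine atom in place of this methoxy would give a value like that of compound 3 or compound 4, and what replacing the remaining methoxy of the 4-methoxyphenyl group with hydrogen would do.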